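This account rests on a few compounds, and the source may have more. Where it says the series, first, only, none or still open, it means among the compounds named here.

Measured compounds:
compound 1, `N/C(=N\NC(=S)N1CCCCCC1)c1ccccn1`, 6000 nM
compound 2, `N/C(=N\NC(=S)N1CCCC1)c1ccc(F)cn1`, 1800 nM
compound 3, `Cc1cccc(/C(N)=N/NC(=S)N2CCOCC2)n1`, 2200 nM

In a functional assay on HeLa cells (Homo sapiens) for cytotoxicity, read by MTT assay, with a stated time of 72 h (on this read-out lower numbers stand for stronger inhibition and higher numbers for weaker inhibition), compound 2 gives the lowest number of the three. Compound 3 comes nearest, within the usual scatter of compound 2, so no order between these two can be read. Compound 1 stands beyond the scatter from compound 2 with its higher number. For the measured compounds named here, no step between single-point changes is available among the measured compounds, so no measured step can be drawn on directly.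

Compound 4, `N/C(=N\NC(=S)N1CCOCC1)c1ccc(F)cn1`, differs from compound 2 in one place: morpholin-4-yl in place of pyrrolidin-1-yl on a thiocarbonyl carbon. The same morpholin-4-yl group is carried by compound 3, which sits within the scatter of compound 2, whereas compound 1, with a different ring on the thiocarbonyl carbon, is the only one beyond it. On this basis compound 4 is expected to stay close to compound 2 in this assay, with a step from compound 2 to compound 4 of a 1.2-fold higher number from compound 2 to compound 4 (0.09 log units; within the scatter), no larger than the scatter. The estimate for compound 4 is 2200 nM, in a range from 900 nM to 5500 nM.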

Compound 4, half-maximal inhibitory concentration: 1700 nM
Estimate against measurement, compound 4: 1.3-fold (0.11 log units) above; the measured number falls inside the stated range.
By their numbers in this assay, from the lowest: compounds 4, 2 and 3 (each within the scatter of the next); then compound 1.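

In this assay, for the compounds shown here, this is the first single-place change that can be read: morpholin-4-yl in place of pyrrolidin-1-yl on a thiocarbonyl carbon gives a 1.1-fold lower number from compound 2 to compound 4 (0.02 log units; within the scatter). On this core, the assay therefore does not separate a five-membered non-aromatic ring with 1 hetero atom from a six-membered one with 2 hetero atoms, and the hydrogen-bond acceptor counted for morpholin-4-yl comes with no readable difference. No measurement at hand bears on why the two rings read alike.

Still open, from the compounds shown here alone, is how this position responds to groups further from these two rings, such as an open-chain dimethylamino group or a piperazin-1-yl ring. Also open, going by these compounds, is whether the same exchange reads alike on the cores of compound 1 and compound 3, which differ from compound 2 in more than one place.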